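The source may report more compounds than this note shows. Statements on the series, on what has been measured and on what is new or still open speak of the compounds shown alone.

Of the compounds shown here, three with related cores have been measured in a physicochemical assay for acid dissociation, using potentiometric titration. Compound 1 `O=c1ccn(CCN2CCCCC2)c(CO)c1O` gives 9.28. Compound 2 `Cc1c(O)c(=O)ccn1CCN(C)C` gives the highest of the three numbers, 9.75. Compound 3 `CC(O)c1c(O)c(=O)ccn1CCN1CCCCC1` gives 8.7. The difference between the core of compound 1 and the core of compound 2 is not broken down here.

Compound 3 is derived from compound 1 by one change, (methyl in place of hydrogen on a saturated chain carbon bound to an aromatic carbon and an oxygen on a saturated carbon). That change moved this assay a number 0.58 log units lower from compound 1 to compound 3 (beyond the scatter). The fourth compound, compound 4 `CCc1c(O)c(=O)ccn1CCN(C)C`, has not yet been measured in this assay. It is derived from compound 2 by methyl in place of hydrogen on a saturated chain carbon bound to an aromatic carbon. This is the same kind of change, a methyl in place of hydrogen, but the surroundings are not the same: in compound 3 the carbon that receives the methyl is bound to an aromatic carbon and an oxygen on a saturated carbon, whereas in compound 4 it is bound only to an aromatic carbon, so the change reads methyl to ethyl rather than hydroxymethyl to 1-hydroxyethyl.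

Going by the values given here, because the one comparable step, a number 0.58 log units lower from compound 1 to compound 3 (beyond the scatter), was measured on a place that is not the same, only a loose expectation can be drawn from it. Compound 4 is expected to move a number 0.15 log units lower from compound 2 to compound 4 (within the scatter), a smaller step than the earlier one. The estimate for compound 4 in this assay is 9.6, with the expected range from 9.2 to 10.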

Compound 4, acid dissociation constant: 9.66
Compound 4: middle estimate off by 0.06 log units, on the low side; the measured number falls inside the stated range.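

In this assay, putting a methyl in place of a hydrogen on the saturated chain carbon bound to an aromatic carbon gives a number 0.09 log units lower from compound 2 to compound 4 (within the scatter), so methyl to ethyl leaves compound 2 and compound 4 indistinguishable on this read-out, whereas the same kind of swap, hydroxymethyl to 1-hydroxyethyl, gave a number 0.58 log units lower from compound 1 to compound 3 (beyond the scatter). Going by these compounds alone, the step therefore did not carry over at full size from one core to the other, which shows that in these two pairs a methyl in place of hydrogen is not a fixed increment; with only one pair on each side, it does not show whether the difference lies with the core or with the oxygen on the carbon that receives the methyl. Nothing measured here bears on why the two steps differ.

The compounds shown leave open whether hydroxymethyl and 1-hydroxyethyl on the core of compound 2 would repeat the larger step, which would separate the role of the core from that of the oxygen. They also leave open how a longer chain such as propyl, or an amine such as aminomethyl, in the place of the ethyl of compound 4 would read in this assay.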